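Series notes: removing the methoxy from compound 3

This account rests on a few compounds, and the source may have more. Where it says the series, first, only, none or still open, it means among the compounds named here.

Of the compounds shown here, three of the shared core have been measured in an assay for inhibition of Polyunsaturated fatty acid 5-lipoxygenase (Homo sapiens), read by spectrophotometry, tested at 50 uM; a lower number here means less inhibition, a higher number more inhibition at the concentration tested (going by the name of the read-out). Compound 1 `O=c1oc(-c2ccc(O)cc2)cc2ccccc12` gives 34.1%. Compound 2 `COc1ccc(-c2cc3ccccc3c(=O)o2)cc1O` gives 65.9%. Compound 3 `COc1cc(O)c2c(=O)oc(-c3ccccc3)cc2c1` gives 49.2%, the second highest of the three numbers; its nearest neighbour is compound 1, lower by a gap beyond the scatter, and compound 2 sits above it by a gap that is also beyond the scatter. Among the measured compounds shown here, no two measured compounds differ in a single place, so no single-step change in this assay is known from the data so far.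

Compound 4 `O=c1oc(-c2ccccc2)cc2cccc(O)c12` differs from compound 3 in one place: hydrogen in place of methoxy on an aromatic carbon. Methoxy leaves, hydrogen enters, at an aromatic carbon of a six-membered aromatic ring of carbon only within the fused system, meta to the hydroxy group. For the measured compounds named here, with no measured step for this change, the estimate for compound 4 is 42% (range 25% to 60%), an expected step of a number 7.2 percentage points lower from compound 3 to compound 4 (within the scatter) that is a modest drop, possibly none beyond the scatter.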

Compound 4, a percentage reported as inhibition, at one concentration (the size of the read-out at that concentration, not a potency): 55.3%
Estimate against measurement, compound 4: 13.3 percentage points below; low and high end bracket the measured number.
By their numbers in this assay, from the lowest: compound 1; then compounds 3 and 4 (each within the scatter of the next); then compound 2.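

In this assay, among the compounds shown here, hydrogen in place of methoxy on this aromatic carbon, meta to a hydroxy group, gives a number 6.1 percentage points higher from compound 3 to compound 4 (within the scatter) and is the first single-place step. For this pair, the number in this assay is level across the loss of the two heavy atoms of the methoxy group, with no change beyond the scatter. Nothing measured on hand accounts for this result.

Going by these compounds, whether an amine, a carboxylic acid or a longer chain such as butoxy on this aromatic carbon would stay within the scatter of compound 4 remains open. Also open, on these data alone, is whether hydrogen in place of methoxy would read the same elsewhere on the shared core, as at the methoxy group of compound 2.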